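Piperidine in Place of Methylpiperazine: an Expected Loss

The compounds below may be only part of what the source reports. "The series", "measured", "known", "first", "only" and "open" are said of these compounds alone.

Of the compounds shown here, two sharing one core have been tested in a functional assay on HeLa cells (Homo sapiens) for inhibition, read by MTT assay, with a stated time of 48 h; on this read-out lower numbers stand for stronger inhibition and higher numbers for weaker inhibition. Compound 1 `O=C1CN(C2CCCC2)c2nc(Nc3ccc(N4CCCCC4)cc3)ncc2N1` gives > 30000 nM, which is a limit of the assay and not a measured number. Within the data shown here, compound 2 `CN1CCN(c2ccc(Nc3ncc4c(n3)N(C3CCCC3)CC(=O)N4C)cc2)CC1` gives 6750 nM in this assay, and this is the only true number so far. The result of compound 1 is a limit, as the limit of > 30000 nM in this assay, at which 1 of the 2 values shown sits, shows. Compound 3 `CN1C(=O)CN(C2CCCC2)c2nc(Nc3ccc(N4CCCCC4)cc3)ncc21` has not yet been measured. It differs from compound 2 by piperidin-1-yl in place of 4-methylpiperazin-1-yl on an aromatic carbon. Among the measured compounds shown here, no measured pair shows this exact change, so the expectation leans on compound 1, which also carries the piperidin-1-yl group and sits at the limit described by the limit of > 30000 nM in this assay, at which 1 of the 2 values shown sits. Compound 3 is therefore expected to be weaker than compound 2, with an estimated step of a 2.7-fold higher number from compound 2 to compound 3 (0.43 log units; beyond the scatter) that goes beyond the usual scatter. Compound 3 is estimated at 18000 nM, within a range from 5000 nM to 40000 nM, with a real chance that only a limit is reported.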

Compound 3, half-maximal inhibitory concentration: 16900 nM
Estimate against measurement, compound 3: 1.1-fold (0.03 log units) above, within the range that was stated.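

In this assay, replacing 4-methylpiperazin-1-yl with piperidin-1-yl on the aromatic carbon now has a measured size, with a 2.5-fold higher number from compound 2 to compound 3 (0.40 log units; beyond the scatter), so this position responds to the change, though modestly, and compound 3 still gives a true number. Adding methyl in place of hydrogen on the amide-type nitrogen in the ring gives an at least 1.7-fold lower number from compound 1 to compound 3 (0.24 log units; that floor lies within the scatter), and with that floor within the scatter, this pair alone does not establish an effect of the methyl. Compound 1 gives a limit and not a number: the limit of > 30000 nM in this assay, at which 1 of the 3 values shown sits.

Still open, as far as these compounds go, is what a morpholine ring or an open-chain amine such as dimethylamino would give on this aromatic carbon. Also open, from the compounds shown here alone, is whether the methyl on the amide-type nitrogen would count for more or less in a compound carrying 4-methylpiperazin-1-yl.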